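A few compounds are considered here, and "the series" means these few. Any claim that something is new, unique, unknown or untested is made for them only; others in the source may bear on it.

Within the data shown here, in a functional assay on MGC-803 cells (Homo sapiens) for inhibition, read by MTT assay, with a stated time of 48 h (a lower number here means a stronger inhibitor, a higher number a weaker inhibitor), compound 3 `C/C=C/C(=O)N(Cc1ccc(OC)c(C)c1)c1cc(OC)c(OC)c(OC)c1` gives 14500 nM, the highest of the three numbers so far. Compound 2 `C/C=C/C(=O)N(Cc1ccc(OC)c(Br)c1)c1cc(OC)c(OC)c(OC)c1` gives 6430 nM, and compound 1 `C#CC(=O)N(Cc1ccc(OC)c(O)c1)c1cc(OC)c(OC)c(OC)c1` gives 170 nM. Compound 4 `C/C=C/C(=O)N(Cc1ccc(OC)c(O)c1)c1cc(OC)c(OC)c(OC)c1` has hydroxy in place of the methyl of compound 3: hydroxy in place of methyl on an aromatic carbon. The change sits on an aromatic carbon, ortho to a methoxy group, and turns 4-methoxy-3-methylphenyl into 3-hydroxy-4-methoxyphenyl. Among the measured compounds shown here, the only measured step at this carbon is a 2.3-fold higher number from compound 2 to compound 3 (0.35 log units; beyond the scatter), a modest one, and it exchanges bromo for methyl, not hydroxy, so it offers only a loose guide. Compound 1 already carries the 3-hydroxy-4-methoxyphenyl group and gives 170 nM, but its group on the carbonyl differs from that of compound 4, so its number cannot simply be carried across. A clear fall in the number is nevertheless expected, larger than the measured step but well short of reaching compound 1. The expected step is a 9.7-fold lower number from compound 3 to compound 4 (0.99 log units; beyond the scatter). Compound 4 is expected at 1500 nM, with an estimated range of 300 nM to 7000 nM.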

Compound 4, half-maximal inhibitory concentration: 27 nM
Compound 4: the middle estimate sits 56-fold (1.74 log units) above what was measured, outside the stated range (below it).
By their numbers in this assay, from the lowest: compound 4; then compound 1; then compound 2; then compound 3.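

In this assay the aromatic carbon ortho to a methoxy group proves far more sensitive than the modest 2.3-fold higher number from compound 2 to compound 3 (0.35 log units; beyond the scatter) could show. Hydroxy in place of methyl gives a 540-fold lower number from compound 3 to compound 4 (2.73 log units; beyond the scatter) and hydroxy in place of bromo gives a 240-fold lower number from compound 2 to compound 4 (2.38 log units; beyond the scatter) as two large steps, so what enters at this carbon sets the number far more than the choice between methyl and bromo does. With the 3-hydroxy-4-methoxyphenyl group held fixed, prop-1-en-1-yl in place of ethynyl on the carbonyl carbon gives a 6.3-fold lower number from compound 1 to compound 4 (0.80 log units; beyond the scatter) as a further, modest step. Nothing available here explains these steps.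

Going by these compounds, whether an amine or a fluoro group at this carbon would keep so low a number remains open. So does how a longer chain on the carbonyl carbon would compare with prop-1-en-1-yl.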